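The source may hold more compounds than are shown below. What is called first, only, known or untested is meant among the compounds shown, and "the series" means these compounds.

Half-lives measured in an ADME assay on a cell-free system (plasma, Mus musculus) for metabolic stability, read by LC-MS, tested at 2 uM; a higher number here means that the compound lasts longer, a lower number that the compound disappears faster:

Compound 1 `CN1CCN(c2ccc3c(c2)oc(=O)n3C(=O)NCCCCc2ccccc2)CC1=O`: 0.333 h
Compound 2 `CCN1CCC(c2ccc3c(c2)oc(=O)n3C(=O)NCCCCc2ccccc2)CC1`: 0.833 h
Compound 3 `CN1CCC(c2cc3oc(=O)n(C(=O)NCCCCc4ccccc4)c3cc2F)CC1`: 0.333 h

Compound 2 has the highest number of the three in this assay; compound 1 and compound 3 both sit lower, and each of those gaps lies beyond the scatter.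

Compound 4 `CN1CCN(c2ccc3c(c2)oc(=O)n3C(=O)NCCCCc2ccccc2)CC1` is not yet measured. Change from compound 2: 4-methylpiperazin-1-yl in place of 1-ethylpiperidin-4-yl on an aromatic carbon

Among the measured compounds shown here, only one measured step bears on this: a 2.5-fold higher number from compound 1 to compound 2 (0.40 log units; beyond the scatter). Compound 4 carries the 4-methylpiperazin-1-yl group, which stands between the groups of compound 1 and compound 2 in the counted atoms. A return toward the number of compound 1 is therefore expected, as a step of a 1.9-fold lower number from compound 2 to compound 4 (0.27 log units; within the scatter). The expected value for compound 4 in this assay is 0.45 h, with a range of 0.2 h to 1 h.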

Compound 4, half-life: < 0.0834 h
Compound 4: a limit, no number; the forecaster's own chance of this, stated with the estimate: 0%; middle value at least 5.3-fold (0.73 log units) away from the limit.
By their numbers in this assay, from the lowest: compounds 1 and 3 (each within the scatter of the next); then compound 2. At a limit, below all of these: compound 4.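

In this assay, 4-methylpiperazin-1-yl on this aromatic carbon gives an at least 9.9-fold lower number from compound 2 to compound 4 (0.99 log units; beyond the scatter), and also an at least 3.9-fold lower number from compound 1 to compound 4 (0.60 log units; beyond the scatter). Compound 4 stands as a limit of the assay, not a number: the limit of < 0.0834 h in this assay, at which 1 of the 4 values shown sits. A group that lies between the other two in counted atoms therefore does not land between them in half-life, and the position responds more sharply than compounds 1 and 2 alone showed.

Still open, on these data alone, is whether the lower number goes with the change of ring or with methyl in place of ethyl. A 4-ethylpiperazin-1-yl group on the same carbon would separate the two.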